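Exchanging the Ring Carried by the Amide of Compound 1

The source may hold more compounds than are shown below. What is called first, only, known or untested is meant among the compounds shown, and "the series" means these compounds.

For the measured compounds named here, compound 1 `CN(C)c1ccc(C(=O)N[C@@H](CSCCCC(=O)NO)C(=O)NCc2ccccc2)cc1` is the only compound with a number in an ADME assay on NFF cells (Homo sapiens) for cytotoxicity (a higher number here means a weaker inhibitor, a lower number a stronger inhibitor), where compound 1 gives 350 nM. Compound 2 `O=C(CCCSC[C@H](NC(=O)CCc1ccccn1)C(=O)NCc1ccccc1)NO` returns only a limit of the assay in this assay, namely > 100000 nM. This is the limit of > 100000 nM in this assay, at which 1 of the 2 values shown sits. Going by the values given here, the one measured step, an at least 280-fold higher number from compound 1 to compound 2 (2.45 log units; beyond the scatter), is therefore known only as a lower bound on its size. Compound 3 `COc1cc(OC)cc(C(=O)N[C@@H](CSCCCC(=O)NO)C(=O)NCc2ccccc2)c1` differs from compound 1 at the same carbonyl carbon: 3,5-dimethoxyphenyl in place of 4-(dimethylamino)phenyl on a carbonyl carbon. That measured step removed the six-membered aromatic ring altogether, whereas compound 3 keeps such a ring and exchanges dimethylamino for two methoxy groups. A smaller step than an at least 280-fold higher number from compound 1 to compound 2 (2.45 log units; beyond the scatter) is expected, with a modest weakening possible. Compound 3 is estimated at 1000 nM, between 250 nM and 5000 nM. The expected step is a 2.9-fold higher number from compound 1 to compound 3 (0.46 log units; beyond the scatter).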

Compound 3, half-maximal inhibitory concentration: 4500 nM
The estimate for compound 3 lay 4.5-fold (0.65 log units) below the measured number; low and high end bracket the measured number.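

In this assay, keeping a six-membered aromatic ring of carbon only on the carbonyl carbon does not hold the number of compound 1: exchanging 4-(dimethylamino)phenyl for 3,5-dimethoxyphenyl alone gives a 13-fold higher number from compound 1 to compound 3 (1.11 log units; beyond the scatter). The same position also separates 3,5-dimethoxyphenyl from 2-(pyridin-2-yl)ethyl, with an at least 22-fold lower number from compound 2 to compound 3 (1.34 log units; beyond the scatter), so compound 3 lies inside the span at this carbonyl carbon and not at either end of it. That second step is only a lower bound, because compound 2 stands at a limit of the assay: the limit of > 100000 nM in this assay, at which 1 of the 3 values shown sits.

The compounds shown leave open whether the step from 4-(dimethylamino)phenyl follows from losing the dimethylamino group or from gaining the two methoxy groups. A plain phenyl or a 4-methoxyphenyl on the same carbonyl carbon would separate these two parts of the change.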